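Bromo to fluoro on the 3-bromobenzyl group

A few compounds are considered here, and "the series" means these few. Any claim that something is new, unique, unknown or untested is made for them only; others in the source may bear on it.

In an ADME assay on CHO-K1 cells (Cricetulus griseus) for cytotoxicity, read by MTT assay, with a stated time of 24 h (on this read-out higher numbers stand for weaker inhibition and lower numbers for stronger inhibition), compound 2 `O=[N+]([O-])c1cc(-c2nnn(Cc3cccc(Br)c3)n2)cc([N+](=O)[O-])c1` gives 29000 nM, and compound 1 `O=[N+]([O-])c1cc(-c2nnn(Cc3ccc(Br)cc3)n2)cc([N+](=O)[O-])c1` gives 55000 nM; the step of a 1.9-fold lower number from compound 1 to compound 2 (0.28 log units; within the scatter) lies within the scatter, so the two numbers are not distinguished from each other. Compound 3 `O=[N+]([O-])c1cc(-c2nnn(Cc3cccc(F)c3)n2)cc([N+](=O)[O-])c1` carries fluoro in place of bromo on an aromatic carbon. Going by the values given here, no measured step exchanges one halogen for another; the single step in hand only moves the bromo and stays within the scatter. The step of a 1.0-fold higher number from compound 2 to compound 3 (0.01 log units; within the scatter) is therefore expected to stay within the scatter, in no particular direction. Compound 3 is estimated at 30000 nM, within a range of 12000 nM to 75000 nM.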

Compound 3, half-maximal inhibitory concentration: 315000 nM
For compound 3 the middle estimate is 11-fold (1.02 log units) below the measured one; the measured number lies above the stated range.
By their numbers in this assay, from the lowest: compounds 2 and 1 (each within the scatter of the next); then compound 3.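

In this assay, the identity of the halogen on the benzyl group separates the compounds where moving the bromo did not: fluoro in place of bromo gives an 11-fold higher number from compound 2 to compound 3 (1.04 log units; beyond the scatter) in this series. The 3-fluorophenyl group also stands apart from the 4-bromophenyl group, with a 5.7-fold higher number from compound 1 to compound 3 (0.76 log units; beyond the scatter) on the same read-out. The data at hand offer no explanation for this separation. Open, from the compounds shown here alone, is whether chloro or iodo at this position stays with the bromo compounds or moves toward compound 3, and where an unsubstituted benzyl group or an amine would fall.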